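Removing the side-chain amine of compound 2

The compounds below may be only part of what the source reports. "The series", "measured", "known", "first", "only" and "open" are said of these compounds alone.

Compound 2 `NCCCC[C@H](NC(=O)CN(c1nc(Cl)nc2[nH]cnc12)C1CC1)C(=O)O` gives 16.3% in a functional assay on the whole organism (Tail, strain ICR) with Mus musculus as the target, in the tail flick test, with a stated time of 30 min, at a dose of 12.5 umol/kg by the oral route (a higher number here means a stronger effect of the compound at the dose given, a lower number a weaker effect), the lower of two numbers, its nearest neighbour being compound 1 `N=C(N)NCCC[C@H](NC(=O)CN(c1nc(Cl)nc2[nH]cnc12)C1CC1)C(=O)O` at 22.2%. Compound 3 `CC(C)C[C@H](NC(=O)CN(c1nc(Cl)nc2[nH]cnc12)C1CC1)C(=O)O` differs from compound 2 by isopropyl in place of 3-aminopropyl on a saturated chain carbon, two bonds along the chain from an amide-type nitrogen and a carbonyl carbon. Within the data shown here, the one measured step that touches this region, a number 5.9 percentage points lower from compound 1 to compound 2 (within the scatter), lay within the scatter, so the data give no sign that this chain end sets the read-out, and no step drops the basic group entirely. Compound 3 is therefore expected to lie near compound 2, with a step of a number 4.3 percentage points lower from compound 2 to compound 3 (within the scatter) that need not exceed the scatter. The estimate for compound 3 is 12%, within 0% to 30%.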

Compound 3, a percentage reported as activity, at one dose (the size of the read-out at that dose, not a potency): 16%
Beside the measured number, compound 3's estimate is 4 percentage points below it; the range from low to high includes it.
By their numbers in this assay, from the lowest: compounds 3, 2 and 1 (each within the scatter of the next).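

Exchanging 3-aminopropyl for isopropyl on this saturated chain carbon gives a number 0.3 percentage points lower from compound 2 to compound 3 (within the scatter) in this assay, and the wider exchange gives a number 6.2 percentage points lower from compound 1 to compound 3 (within the scatter). A chain end with no nitrogen and no hydrogen-bond donor or acceptor therefore reads the same, within the scatter, as both nitrogen-bearing chain ends, which the earlier step alone could not show. No measurement here offers a cause for this. From the compounds shown here alone, whether a phenyl ring, a carboxylic acid or a longer chain at this carbon would move the read-out beyond the scatter stays open.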